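This account rests on a few compounds, and the source may have more. Where it says the series, first, only, none or still open, it means among the compounds named here.

In a functional assay on A549 cells (Homo sapiens) for cytotoxicity, read by MTT assay, with a stated time of 48 h (on this read-out lower numbers stand for stronger inhibition and higher numbers for weaker inhibition), three compounds that share one sugar-derived core have been measured. Compound 1 `CCCCCCCCCC1(CO[C@@H]2O[C@@H]3CO[C@H](c4ccccc4)O[C@@H]3[C@H](OCc3ccccc3)[C@H]2OCc2ccccc2)CN1S(=O)(=O)c1ccc(C)cc1` gives 154000 nM in this assay. Compound 2 `Cc1ccc(S(=O)(=O)N2CC2CO[C@@H]2O[C@@H]3CO[C@H](c4ccccc4)O[C@@H]3[C@H](OCc3ccccc3)[C@H]2OCc2ccccc2)cc1` differs from compound 1 at a single saturated ring carbon; in this assay compound 2 gives 73000 nM, and the step of a 2.1-fold lower number from compound 1 to compound 2 (0.32 log units; beyond the scatter) is a modest move toward stronger inhibition. Compound 3 `Cc1ccc(S(=O)(=O)N2C(C)C2CO[C@@H]2O[C@@H]3CO[C@H](c4ccccc4)O[C@@H]3[C@H](O)[C@H]2O)cc1` gives 351000 nM in this assay, the highest number of the three: compound 1 lies nearest to it and compound 2 furthest, both separated from it by more than the scatter. Compound 3 is not joined to either of the others by a single-change step, so those gaps say only what the two values show.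

Compound 4 `Cc1ccc(S(=O)(=O)N2C(CO[C@@H]3O[C@@H]4CO[C@H](c5ccccc5)O[C@@H]4[C@H](O)[C@H]3O)C2(C)C)cc1` differs from compound 3 by methyl in place of hydrogen on a saturated ring carbon. Among the measured compounds shown here, the only measured step at a saturated ring carbon of this core is a 2.1-fold lower number from compound 1 to compound 2 (0.32 log units; beyond the scatter), where taking away a nonyl chain produced a modest change; here a much smaller group is added rather than removed. A change in this assay of no more than the scatter is therefore expected, with a slight rise in number more likely than a fall. Compound 4 is accordingly estimated at 400000 nM, within 160000 nM to 1000000 nM, a step of a 1.1-fold higher number from compound 3 to compound 4 (0.06 log units; within the scatter).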

Compound 4, half-maximal inhibitory concentration: 389000 nM
The estimate for compound 4 lay 1.0-fold (0.01 log units) above the measured number; low and high end bracket the measured number.
By their numbers in this assay, from the lowest: compound 2; then compound 1; then compounds 3 and 4 (each within the scatter of the next).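

Placing a methyl on this saturated ring carbon of the three-membered non-aromatic ring, where a hydrogen stood, gives a 1.1-fold higher number from compound 3 to compound 4 (0.04 log units; within the scatter) in this assay. The earlier step at a saturated ring carbon, a 2.1-fold lower number from compound 1 to compound 2 (0.32 log units; beyond the scatter), involved a nonyl chain and lay beyond the scatter, whereas this first measurement of a single added carbon shows no change that can be told apart from repeat-to-repeat variation. The data on hand give no measured explanation for either step, so the reason for this result remains unknown.

These two steps were measured on different compounds, with the nonyl step in a compound carrying benzyl groups on the sugar and the methyl step in a compound carrying free hydroxyl groups, so they do not show whether the size of the group alone sets the size of the change. The compounds shown leave open what a longer chain such as nonyl, or a group of a different kind such as an amine or a carboxylic acid, would do on this same ring carbon.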